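Chloropyridinyl amide variant of the biaryl chromenone series

The source may report more compounds than this note shows. Statements on the series, on what has been measured and on what is new or still open speak of the compounds shown alone.

Measured so far:
- compound 1, `O=C(Nc1cccc(-c2oc3cc(-c4ccc(F)cc4)ccc3c(=O)c2O)c1)c1ccc(F)cc1`: in a functional assay on A549 cells (Homo sapiens) for antiproliferative activity, read by CCK-8 assay, with a stated time of 72 h (a higher number here means a weaker inhibitor, a lower number a stronger inhibitor), compound 1 gives 6930 nM
- compound 2, `Cc1ccc(C(=O)Nc2cccc(-c3oc4cc(-c5ccc(F)cc5)ccc4c(=O)c3O)c2)cc1`: in this assay compound 2 gives 6910 nM

For the measured compounds named here, compound 1 holds the highest of the two numbers in this assay, but its nearest neighbour, compound 2, is within the scatter of it: the single step in hand, a 1.0-fold lower number from compound 1 to compound 2 (0.00 log units; within the scatter), changes nothing beyond noise. The series therefore shows, so far, that swapping one substituent for another on the terminal aromatic ring of the amide leaves the read-out flat.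

Compound 3, `O=C(Nc1cccc(-c2oc3cc(-c4ccc(F)cc4)ccc3c(=O)c2O)c1)c1ccc(Cl)nc1`, is the next point. Relative to compound 1 the change is 6-chloropyridin-3-yl in place of 4-fluorophenyl on a carbonyl carbon. Going by the values given here, no measured step involves a ring with a hetero atom in this position, so the only relevant comparison is the substituent swap above, which was flat. On that basis no shift beyond the scatter is expected in this assay; the expected step is a 1.0-fold higher number from compound 1 to compound 3 (0.00 log units; within the scatter). Compound 3 is thus estimated to give 7000 nM, with a range from 3000 nM to 16000 nM.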

Compound 3, half-maximal inhibitory concentration: 3580 nM
The estimate for compound 3 lay 2.0-fold (0.29 log units) above the measured number; the range from low to high includes it.
By their numbers in this assay, from the lowest: compounds 3, 2 and 1 (each within the scatter of the next).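

In this assay, for the compounds shown here, the position on the carbonyl carbon now carries a ring with a hetero atom, which the earlier compounds did not show. The change to 6-chloropyridin-3-yl from 4-fluorophenyl gives (a 1.9-fold lower number from compound 1 to compound 3 (0.29 log units; within the scatter)), and the change from 4-methylphenyl gives (a 1.9-fold lower number from compound 2 to compound 3 (0.29 log units; within the scatter)), so neither step separates compound 3 from the two earlier amides, and the flat picture now covers three different six-membered aromatic rings at this place, one of them with a hetero atom and a hydrogen-bond acceptor. No supporting measurement bears on this result, so nothing can be said about what lies behind the read-out at this position.

Going by these compounds alone, the single change in compound 3 brings in the ring nitrogen and the chlorine together, so the contribution of each stays unresolved; 4-chlorophenyl and unsubstituted pyridin-3-yl on the same carbonyl carbon would separate them. Going by these compounds, it also remains open whether the read-out at this place stays flat for groups of a different kind, such as a carboxylic acid or a dimethylamino group on the ring, or a saturated piperidine ring or a longer alkyl chain in place of the aromatic ring.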